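Side-chain amine variant of the chloro compound

The compounds below may be only part of what the source reports. "The series", "measured", "known", "first", "only" and "open" are said of these compounds alone.

Both measured compounds of the series carry a butylamino chain on the shared core and differ only in the ring halogen. Compound 1 `CCCCNc1ccnc2cc(Cl)ccc12` gives 6020 nM in a functional assay on MDA-MB-468 cells (Homo sapiens) for cytotoxicity, read by sulforhodamine B assay, with a stated time of 48 h (a lower number here means a stronger inhibitor of growth, a higher number a weaker inhibitor of growth), the highest of the two numbers recorded. Within the data shown here, compound 2 `CCCCNc1ccnc2cc(F)ccc12` gives 1410 nM in this assay, and the step of a 4.3-fold lower number from compound 1 to compound 2 (0.63 log units; beyond the scatter) is the only measured step in the set.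

Compound 3 `CN(C)CCNc1ccnc2cc(Cl)ccc12` keeps the chloro ring of compound 1 and changes the chain instead: dimethylamino in place of ethyl on a saturated chain carbon, two bonds along the chain from a nitrogen on an aromatic ring. Among the measured compounds shown here, no measured step touches the chain; the single recorded step concerns the ring halogen and so says nothing about this change. Without a comparable precedent, the expectation for compound 3 rests on compound 1 alone, and the estimated step of a 1.5-fold lower number from compound 1 to compound 3 (0.18 log units; within the scatter) is kept small, with the direction left open and a wide range. In this assay compound 3 is therefore expected at about 4000 nM, with a likely span from 1000 nM to 15000 nM.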

Compound 3, concentration for 50% growth inhibition: 13300 nM
For compound 3 the middle estimate is 3.3-fold (0.52 log units) below the measured one; the range from low to high includes it.
By their numbers in this assay, from the lowest: compound 2; then compound 1; then compound 3.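

In this assay the chain is not a silent position: a 2.2-fold higher number from compound 1 to compound 3 (0.34 log units; beyond the scatter), so on the chloro compound, butyl to 2-(dimethylamino)ethyl moves the number toward weaker inhibition of growth. Among these compounds, this is the first measured change away from the ring halogen, and the step is modest and beyond the scatter, so the dimethylamino group is tolerated at this place on a saturated chain carbon, with a measurable loss but not an abolished effect. Nothing available on these compounds accounts for the direction or the size of this step.

Going by these compounds, whether the same chain change gives a step of like direction and size on the fluoro compound stays open, as 2-(dimethylamino)ethyl appears here only with the chloro ring. On these data alone, it is equally open how a 3-(dimethylamino)propyl chain, a 2-(diethylamino)ethyl chain or a 2-hydroxyethyl chain in place of butyl would read, so one chain change on one ring gives a single point and no trend along the chain.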